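The source may hold more compounds than are shown below. What is called first, only, known or untested is meant among the compounds shown, and "the series" means these compounds.

Measured compounds in an assay on isolated protein for inhibition of 11-beta-hydroxysteroid dehydrogenase type 2 (Homo sapiens); a lower number here means a stronger inhibitor, a higher number a weaker inhibitor:

compound 1 `Cn1c(-c2ccc(C(=O)NC3CC3)cc2)nnc1C1(c2ccc(Cl)cc2)CCC1`, giving > 4000 nM
compound 2 `Cn1c(-c2ccc(C(N)=O)cc2C(N)=O)nnc1C1(c2ccc(Cl)cc2)CCC1`, giving > 4000 nM
compound 3 `Cn1c(-c2ccc(N)cc2Cl)nnc1C1(c2ccc(Cl)cc2)CCC1`, giving 2300 nM

The value for compound 1 is a limit of this assay, not a number. The value for compound 2 is likewise a limit. Only compound 3 returns a number in this assay, and that number is weak. Compound 1 therefore stands at the top edge of what this assay reports, with no measured step in the series to place it more closely: the shared core carries, across all three compounds, only weak or unmeasurable inhibition, as shown by the limit of > 4000 nM in this assay, at which 2 of the 3 values shown sit.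

The next compound is compound 4 `Cc1noc(C)c1-c1ccc(-c2nnc(C3(c4ccc(Cl)cc4)CCC3)n2C)cc1`. It differs from compound 1 in one place: 3,5-dimethyl-1,2-oxazol-4-yl in place of cyclopropylcarbamoyl on an aromatic carbon. Without any measured pair that differs in one place, the size of the step from compound 1 to compound 4 cannot be taken from the data. With two of three values at the limit and the third only modestly inside it, no step beyond the scatter is expected in either direction; the expected step is an at least 1.3-fold lower number from compound 1 to compound 4 (0.12 log units; that floor lies within the scatter). Compound 4 is therefore estimated at 3000 nM, within a range from 600 nM to 15000 nM, with a fair chance that this assay again reports only a limit.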

Compound 4, half-maximal inhibitory concentration: > 4000 nM
Compound 4: no number, only a limit; the forecaster's own chance of this, stated with the estimate: 45%; at least 1.3-fold (0.12 log units) between middle value and limit.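

In this assay compound 4 gives > 4000 nM, which is a limit and not a number. Compound 1 also gives only a limit, so no step can be read from compound 1 to compound 4. The compounds shown leave open whether 3,5-dimethyl-1,2-oxazol-4-yl in place of cyclopropylcarbamoyl changes inhibition at all, with most of the series at the edge of the read-out: the limit of > 4000 nM in this assay, at which 3 of the 4 values shown sit.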